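The source may hold more compounds than are shown below. What is called first, only, known or untested is meant among the compounds shown, and "the series" means these compounds.

Measured compounds in a functional assay on MGC-803 cells (Homo sapiens) for antiproliferative activity, read by CCK-8 assay, with a stated time of 72 h, tested at 8 uM; on this read-out higher numbers stand for a stronger effect at the one concentration tested and lower numbers for a weaker effect:
compound 1 `CN(Cc1cccnc1)C(=S)SCc1ccc(C(=O)Nc2ccccc2N)cc1`, 85.5%
compound 2 `Nc1ccccc1NC(=O)c1ccc(CSC(=S)N2CCN(Cc3ccccc3)CC2)cc1`, 19.7%
compound 3 `Nc1ccccc1NC(=O)c1ccc(CSC(=S)N2CCN(c3ccccc3F)CC2)cc1`, 86.4%

Compound 1 stands second highest of the three numbers in this assay. Its nearest neighbour is compound 3, within the scatter of each other, while compound 2 lies far below both. Within the data shown here, the one step between measured compounds that differ in a single place is a number 66.7 percentage points higher from compound 2 to compound 3 (beyond the scatter), a change of the group on the amine nitrogen in the piperazine ring from benzyl to 2-fluorophenyl.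

Compound 4 `CN1CCN(C(=S)SCc2ccc(C(=O)Nc3ccccc3N)cc2)CC1` is not yet measured. It differs from compound 1 in one place: 4-methylpiperazin-1-yl in place of methyl((pyridin-3-yl)methyl)amino on a thiocarbonyl carbon. The thiocarbonyl carbon thus again carries a piperazine ring, as in compound 2 and compound 3, but this time as 4-methylpiperazin-1-yl, a group not seen among the measured compounds.

The step from compound 2 to compound 3 bears on this only indirectly: it shows that a piperazine ring on the thiocarbonyl carbon can give either a very low or a high number in this assay depending on what it carries, and neither benzyl nor 2-fluorophenyl matches the methyl of compound 4. Among the measured compounds shown here, no measured step tests the change from compound 1 to compound 4 directly, so the direction is open; a fall from compound 1 is as plausible as a number near it. Compound 4 is expected to give about 50%, within 15% to 85%, which is expected to amount to a number 35.5 percentage points lower from compound 1 to compound 4 (beyond the scatter).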

Compound 4, a percentage reported as inhibition, at one concentration (the size of the read-out at that concentration, not a potency): 84.4%
For compound 4 the middle estimate is 34.4 percentage points below the measured one, and the stated range covers the measured number.
By their numbers in this assay, from the lowest: compound 2; then compounds 4, 1 and 3 (each within the scatter of the next).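

In this assay, the thiocarbonyl carbon tolerates 4-methylpiperazin-1-yl in place of methyl((pyridin-3-yl)methyl)amino, with a number 1.1 percentage points lower from compound 1 to compound 4 (within the scatter), so in this pair a high number does not depend on the six-membered aromatic ring of the group that leaves. On the amine nitrogen in the ring, methyl in place of 2-fluorophenyl gives a number 2 percentage points lower from compound 3 to compound 4 (within the scatter), whereas the comparison with the benzyl compound gives a number 64.7 percentage points higher from compound 2 to compound 4 (beyond the scatter), which places compound 2 alone among the piperazine compounds and shows that the ring on the thiocarbonyl carbon does not by itself bring a low number. No supporting measurement bears on what sets the benzyl group apart.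

As far as these compounds go, whether the low number of compound 2 follows from the chain carbon of benzyl or from its unsubstituted phenyl ring stays open, and 2-phenylethyl, 2-fluorobenzyl or plain hydrogen on that ring nitrogen would separate these readings. Since compounds 1, 3 and 4 lie within the scatter of each other at a single concentration, the compounds shown also leave any ranking among them open, as well as whether a morpholine ring would serve on the thiocarbonyl carbon.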